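The compounds below may be only part of what the source reports. "The series", "measured", "known", "first", "only" and "open" are said of these compounds alone.

Measured so far in an assay for inhibition of 17-beta-hydroxysteroid dehydrogenase type 2 (Homo sapiens), read by HPLC, with a stated time of 10 min, tested at 1 uM; on this read-out lower numbers stand for less inhibition and higher numbers for more inhibition at the one concentration tested (going by the name of the read-out):
compound 1 `CN(c1ccc(F)c(O)c1)c1cccc(-c2cccc(O)c2F)n1` gives 100%
compound 2 `N#Cc1ccc2ccc(C(=O)c3ccc(F)c(O)c3)nc2c1` gives 56%
compound 3 `Oc1cc(Nc2cccc(-c3cccc(O)c3F)n2)ccc1F` gives 82%

Compound 2 stands lowest of the three numbers in this assay. Its nearest neighbour is compound 3, whose number lies beyond the scatter above it; compound 1 lies further still, also beyond the scatter. For the measured compounds named here, the one step measured, a number 18 percentage points lower from compound 1 to compound 3 (beyond the scatter), concerns hydrogen in place of methyl on a nitrogen on an aromatic ring, a change at a different place and of a different kind than the one now in question, so it gives no direct guidance.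

Compound 4 `Nc1ccc2ccc(C(=O)c3ccc(F)c(O)c3)nc2c1` differs from compound 2 by amino in place of cyano on an aromatic carbon. Going by the values given here, no measured pair shows an exchange of this kind on the shared core of compound 2 and compound 4, so there is nothing to scale an expectation against, and the working assumption is a step not beyond the scatter. The expected step is therefore a number 4 percentage points lower from compound 2 to compound 4 (within the scatter). On that basis compound 4 is estimated at 52%, with a range from 28% to 76% in this assay.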

Compound 4, a percentage reported as inhibition, at one concentration (the size of the read-out at that concentration, not a potency): 83%
Estimate against measurement, compound 4: 31 percentage points below; measured number outside the range, above it.
By their numbers in this assay, from the lowest: compound 2; then compounds 3 and 4 (each within the scatter of the next); then compound 1.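

In this assay, the exchange at this aromatic carbon, meta to a fused ring and para to a fused ring, is not silent on the shared core: amino in place of cyano gives a number 27 percentage points higher from compound 2 to compound 4 (beyond the scatter). The earlier step, on a nitrogen on an aromatic ring, said nothing about this place, which now shows that a single exchange here can move the read-out beyond the scatter. Nothing at hand explains the step.

This single pair cannot separate a contribution of the entering amino from one of the leaving cyano. From the compounds shown here alone, whether a methylamino, a hydroxyl or a carboxylic acid on the same carbon would sit nearer compound 2 or compound 4 remains open, as does the read-out of the unsubstituted carbon.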